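Bis(hydroxyphenyl)pyridines with a furyl group: cytotoxicity notes

This account rests on a few compounds, and the source may have more. Where it says the series, first, only, none or still open, it means among the compounds named here.

Compound 1 `Oc1ccccc1-c1cc(-c2ccco2)cc(-c2ccccc2O)n1` was tested in a functional assay on HeLa cells (Homo sapiens) for cytotoxicity, read by CCK-8 assay; on this read-out higher numbers stand for weaker inhibition and lower numbers for stronger inhibition. In this assay compound 1 gives only a limit, > 50000 nM. Compound 2 `Oc1cccc(-c2cc(-c3ccco3)cc(-c3ccccc3O)n2)c1` carries the change 3-hydroxyphenyl in place of 2-hydroxyphenyl on an aromatic carbon and also gives only a limit in this assay, > 50000 nM. The step that the two limits leave unreadable from compound 1 to compound 2 is therefore not readable. Compound 3 `Oc1cccc(-c2cc(-c3ccoc3)cc(-c3ccccc3O)n2)c1` likewise gives only a limit in this assay, > 50000 nM; the difference between the cores of compound 1 and compound 3 is not broken down here, and the step that the two limits leave unreadable from compound 2 to compound 3 is not readable either. All three values sit at the same limit (the limit of > 50000 nM in this assay, at which 3 of the 3 values shown sit).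

Compound 4 `Oc1cccc(-c2cc(-c3ccoc3)cc(-c3cccc(O)c3)n2)c1` is not yet measured. It carries 3-hydroxyphenyl in place of 2-hydroxyphenyl on an aromatic carbon; the place differs from the earlier case, being meta to a 3-hydroxyphenyl group and to a furan-3-yl group rather than to a 2-hydroxyphenyl group and a furan-2-yl group, so it is the same kind of change, not the same. Since compound 1, compound 2 and compound 3 all sit at the limit (the limit of > 50000 nM in this assay, at which 3 of the 3 values shown sit), the step from compound 3 to compound 4 is expected to be a step that the limit leaves unreadable from compound 3 to compound 4 and most likely to stay unreadable. Compound 4 is estimated at 80000 nM in this assay, within 40000 nM to 200000 nM.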

Compound 4, half-maximal inhibitory concentration: 4630 nM
Compound 4: middle estimate off by 17-fold (1.24 log units), on the high side; measured number below the stated range.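

In this assay, 3-hydroxyphenyl in place of 2-hydroxyphenyl on the core of compound 3 gives an at least 10-fold lower number from compound 3 to compound 4 (1.03 log units; beyond the scatter). This is a single readable case, and it does not show that the change carries over from one core to another. The same change on the core of compound 1 cannot be read, so the two cases cannot be compared: the limit of > 50000 nM in this assay, at which 3 of the 4 values shown sit.

As far as these compounds go, it remains open whether the furan-2-yl counterpart of compound 4 would also leave the limit, which would separate the role of the furan from that of the hydroxyphenyl change. From the compounds shown here alone, it is also open whether an amine or a carboxylic acid in place of the hydroxyl on the 3-hydroxyphenyl groups would retain the value of compound 4, the 4630 nM measured here.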